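Methoxy for hydroxy on the urea-bearing series member

This account rests on a few compounds, and the source may have more. Where it says the series, first, only, none or still open, it means among the compounds named here.

Of the compounds shown here, two of the shared core have been measured in a functional assay on OVCAR-8 cells (Homo sapiens) for inhibition, read by sulforhodamine B assay, with a stated time of 48 h, tested at 10 uM; a higher number here means a weaker effect of the compound at the concentration tested, a lower number a stronger effect. Compound 1 `COc1cc(Cl)cc(-c2nn(-c3cccc(NC(=O)c4ccc(Cl)c(Cl)c4)c3)cc2-c2ccncc2)c1` gives 58.4%. Compound 2 `O=C(Nc1cccc(-n2cc(-c3ccncc3)c(-c3cc(O)cc(Cl)c3)n2)c1)Nc1ccc(Cl)c(C(F)(F)F)c1` gives 3.69%, the lowest of the two numbers; its gap to compound 1 lies beyond the scatter. Going by the values given here, the two differ in more than one place, so no single step between them can be read; the values stand on their own.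

Compound 3 `COc1cc(Cl)cc(-c2nn(-c3cccc(NC(=O)Nc4ccc(Cl)c(C(F)(F)F)c4)c3)cc2-c2ccncc2)c1` is the unmeasured member. It differs from compound 2 by methyl in place of hydrogen on an oxygen on an aromatic ring, that is hydroxy to methoxy, 3-chloro-5-hydroxyphenyl to 3-chloro-5-methoxyphenyl. Among the compounds with values here, the only other methoxy-bearing member, compound 1, gives 58.4% in this assay, but its further differences leave the effect of this change alone unknown. For compound 3 the step is expected to be an upward one of a number 16.3 percentage points higher from compound 2 to compound 3 (beyond the scatter), with wide uncertainty. The expected value for compound 3 in this assay is 20%, within 3% to 55%.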

Compound 3, a percentage reported as activity, at one concentration (the size of the read-out at that concentration, not a potency): 8.71%
Estimate against measurement, compound 3: 11.3 percentage points above; measured number inside the range.
By their numbers in this assay, from the lowest: compounds 2 and 3 (each within the scatter of the next); then compound 1.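

In this assay, methyl in place of hydrogen on the oxygen gives a number 5 percentage points higher from compound 2 to compound 3 (within the scatter), so in this urea-bearing pair the free hydroxy on the 3-chloro-5-hydroxyphenyl group is not required for the effect at the concentration tested. Going by these compounds alone, the methoxy group alone therefore does not set compound 1 apart, since the single change of (4-chloro-3-(trifluoromethyl)phenyl)amino in place of 3,4-dichlorophenyl on a carbonyl carbon gives a number 49.7 percentage points lower from compound 1 to compound 3 (beyond the scatter). No supporting measurement accounts for the size of either step.

The compounds shown leave open whether a longer chain on this oxygen, or an amine in place of the hydroxy, stays within the scatter of compound 2. They also leave open whether hydroxy to methoxy reads the same on the carbonyl substituent of compound 1.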